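The source may hold more compounds than are shown below. What is called first, only, known or untested is meant among the compounds shown, and "the series" means these compounds.

Of the compounds shown here, three that share one core have been measured in a physicochemical assay for solubility, read by nephelometry, measured as kinetic solubility, with a stated time of 30 min; a lower number here means a less soluble compound, a higher number a more soluble compound. Compound 1 `N[C@H]1CC[C@@H](Oc2ccc([C@H]3CC[C@]4(CC3)OOC3(O4)C4CC5CC(C4)CC3C5)cc2)CC1` gives 25 ug/mL. Compound 2 `CS(=O)(=O)N1CCN(CCCOc2ccc([C@H]3CC[C@]4(CC3)OOC3(O4)C4CC5CC(C4)CC3C5)cc2)CC1` sits at a limit of the assay, < 1.6 ug/mL. Compound 3 `O[C@H]1CC[C@H](NCCCOc2ccc([C@H]3CC[C@]4(CC3)OOC3(O4)C4CC5CC(C4)CC3C5)cc2)CC1` also sits at a limit, this time the upper one, > 100 ug/mL. Two measured steps lead to it: an at least 4.0-fold higher number from compound 1 to compound 3 (0.60 log units; beyond the scatter) and an at least 62-fold higher number from compound 2 to compound 3 (1.79 log units; beyond the scatter), both changing the side chain that carries the amine nitrogen. Compound 4 `CC(C)(O)CNCCCOc1ccc([C@H]2CC[C@]3(CC2)OOC2(O3)C3CC4CC(C3)CC2C4)cc1` keeps that amine nitrogen and a hydroxyl group, with the change (2-hydroxy-2-methylpropyl in place of 4-hydroxycyclohexyl on an amine nitrogen). Neither measured step tests this exact exchange, so the change is expected to give a number no higher from compound 3 to compound 4 (the limit leaves the size open), nothing beyond the scatter. Compound 4 is therefore estimated at 100 ug/mL, somewhere between 40 ug/mL and 200 ug/mL, quite possibly again at the limit.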

Compound 4, solubility: > 100 ug/mL
Compound 4 gave a limit, no number; the forecaster's own chance of this, stated with the estimate: 55%; the middle value sits exactly at the limit.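

Compound 4, with 2-hydroxy-2-methylpropyl and no ring on the amine nitrogen, also sits at the upper limit of this assay, so the ring of 4-hydroxycyclohexyl is not required for a reading at this limit: the limit of > 100 ug/mL in this assay, at which 2 of the 4 values shown sit.

Compound 4 also stands well clear of the two lower compounds, with an at least 62-fold higher number from compound 2 to compound 4 (1.79 log units; beyond the scatter) and an at least 4.0-fold higher number from compound 1 to compound 4 (0.60 log units; beyond the scatter). The step between compound 3 and compound 4 cannot be read, as both values are limits.

Which of these two side chains gives the higher number therefore stays open. Also open, going by these compounds, is how an isobutyl group, lacking the hydroxyl, or a carboxylic acid on this amine nitrogen would read.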